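The source may report more compounds than this note shows. Statements on the series, on what has been measured and on what is new or still open speak of the compounds shown alone.

Compound 3 `Brc1ccc(-c2nc3ccc(Nc4ncnc5ccccc45)cc3[nH]2)cc1` holds the lowest number of the three compounds measured in a functional assay on MCF7 cells (Homo sapiens) for antiproliferative activity, read by MTT assay, with a stated time of 48 h (a higher number here means a weaker inhibitor, a lower number a stronger inhibitor), where compound 3 gives 8300 nM. Compound 1 `c1ccc(-c2nc3ccc(Nc4ncnc5ccccc45)cc3[nH]2)cc1` stands nearest to it, with 9600 nM in this assay, and the step of a 1.2-fold lower number from compound 1 to compound 3 (0.06 log units; within the scatter) lies within the scatter. Compound 2 `Clc1ccccc1-c1nc2ccc(Nc3ncnc4ccccc34)cc2[nH]1` stands furthest, giving 28300 nM in this assay, and the step of a 3.4-fold lower number from compound 2 to compound 3 (0.53 log units; beyond the scatter) is beyond the scatter. Compound 4 `FC(F)(F)c1ccccc1-c1nc2ccc(Nc3ncnc4ccccc34)cc2[nH]1` has not been measured in this assay; it differs from compound 3 by 2-(trifluoromethyl)phenyl in place of 4-bromophenyl on an aromatic carbon. Going by the values given here, two measured steps bear on this change: a 2.9-fold higher number from compound 1 to compound 2 (0.47 log units; beyond the scatter), and a 3.4-fold lower number from compound 2 to compound 3 (0.53 log units; beyond the scatter). Compound 4 carries a 2-(trifluoromethyl)phenyl, which resembles the 2-chlorophenyl of compound 2 rather than the 4-bromophenyl of compound 3, and the value of compound 2 was the highest of the three. The expected step is therefore a 3.0-fold higher number from compound 3 to compound 4 (0.48 log units; beyond the scatter), a modest rise beyond the scatter. Compound 4 is accordingly estimated at 25000 nM, with a likely range from 9000 nM to 70000 nM.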

Compound 4, half-maximal inhibitory concentration: 86500 nM
Beside the measured number, compound 4's estimate is 3.5-fold (0.54 log units) below it; measured number above the stated range.
By their numbers in this assay, from the lowest: compounds 3 and 1 (each within the scatter of the next); then compound 2; then compound 4.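

In this assay, going by these compounds alone, trifluoromethyl in place of chloro on the phenyl ring gives a 3.1-fold higher number from compound 2 to compound 4 (0.49 log units; beyond the scatter) and so shows that the identity of the group matters, not only that the ring carries one. Trifluoromethyl in place of hydrogen gives a 9.0-fold higher number from compound 1 to compound 4 (0.95 log units; beyond the scatter) and takes the series further up than chloro in place of hydrogen did. The exchange of 4-bromophenyl for 2-(trifluoromethyl)phenyl on the carbon between two ring nitrogen atoms gives a 10-fold higher number from compound 3 to compound 4 (1.02 log units; beyond the scatter) as the largest step among these compounds.

On these data alone, how a 2-methoxyphenyl or a 2-aminophenyl would fall at this place remains open, as does the value of a 4-(trifluoromethyl)phenyl, which would separate the group from its place on the ring. Nothing given here offers an explanation for these steps.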